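This account rests on a few compounds, and the source may have more. Where it says the series, first, only, none or still open, it means among the compounds named here.

Compound 1, `CN1CCN(c2ccc(C3=NN(C(=O)c4ccc(C(F)(F)F)cc4)C(c4ccc(N(C)C)cc4)C3)cc2)CC1`, gives 84.1% in a functional assay on HCC1806 cells (Homo sapiens) for inhibition, read by sulforhodamine B assay, tested at 10 uM (a higher number here means more inhibition at the concentration tested (going by the name of the read-out), a lower number less inhibition), which is the second highest of the three values measured. Its nearest neighbour is compound 3, `CN1CCN(c2ccc(C3=NN(S(=O)(=O)c4ccc(Br)cc4)C(c4ccc(N(C)C)cc4)C3)cc2)CC1`, whose value of 87.1% sits a number 3 percentage points higher from compound 1 to compound 3 (within the scatter). The furthest is compound 2, `CN1CCN(c2ccc(C3=NN(S(C)(=O)=O)C(c4ccc(N(C)C)cc4)C3)cc2)CC1`, at -18.5%, a change of a number 102.6 percentage points lower from compound 1 to compound 2 (beyond the scatter); between those two, the step runs a number 105.6 percentage points higher from compound 2 to compound 3 (beyond the scatter).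

Compound 4, `CN(C)c1ccc(C2CC(c3ccc(-n4cncn4)cc3)=NN2C(=O)c2ccc(C(F)(F)F)cc2)cc1`, differs from compound 1 by 1H-1,2,4-triazol-1-yl in place of 4-methylpiperazin-1-yl on an aromatic carbon. Going by the values given here, all three measured steps vary the group on the ring nitrogen of the shared core, so none of them bears on this change at the aromatic carbon, and no measured pair shows what this exchange does in this assay. With no guidance of that kind, compound 4 is expected to stay near compound 1, but with wide uncertainty, and a step of a number 14.1 percentage points lower from compound 1 to compound 4 (beyond the scatter) is estimated. For compound 4 the estimate in this assay is 70%, expected to lie between 30% and 95%.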

Compound 4, a percentage reported as inhibition, at one concentration (the size of the read-out at that concentration, not a potency): 7%
The estimate for compound 4 lay 63 percentage points above the measured number; measured number below the stated range.
By their numbers in this assay, from the lowest: compound 2; then compound 4; then compounds 1 and 3 (each within the scatter of the next).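

In this assay, replacing 4-methylpiperazin-1-yl with 1H-1,2,4-triazol-1-yl on the aromatic carbon gives a step of a number 77.1 percentage points lower from compound 1 to compound 4 (beyond the scatter). Going by these compounds alone, the earlier steps varied only the group on the ring nitrogen, so this is the first sign that the group at this other position, para to a large group, also strongly affects the read-out while (4-(trifluoromethyl)phenyl)carbonyl stays in place. No available evidence accounts for the size of this step.

The compounds shown leave open whether the drop follows from losing 4-methylpiperazin-1-yl or from introducing 1H-1,2,4-triazol-1-yl, a question that a morpholine or piperidine ring at the same place could help separate. They also leave open whether the same exchange would have a similar effect with (4-bromophenyl)sulfonyl on the ring nitrogen, the group carried by compound 3.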